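Cyclohexylsulfanyl in place of cyclopentyloxy: effect on cell toxicity

The source may hold more compounds than are shown below. What is called first, only, known or untested is meant among the compounds shown, and "the series" means these compounds.

Measured in an ADME assay on MT4 cells (Homo sapiens) for cytotoxicity, read by MTT assay; on this read-out higher numbers stand for lower toxicity in this test and lower numbers for higher toxicity in this test:
- compound 1 `Cc1cc(OC2CCCC2)nc(Nc2ccc(C#N)cc2)n1`: 1050 nM
- compound 2 `Cc1cc(SC2CCCCC2)nc(Nc2ccc(C#N)cc2)n1`: >= 192000 nM, which is a limit of the assay and not a number
- compound 3 `Cc1cnc(Nc2ccc(C#N)cc2)nc1OC1CCCC1`: 9990 nM

Compound 1 and compound 3 contain the same atoms joined differently; how the two cores differ is not broken down here. In this assay compound 3 gives 9990 nM while compound 1 gives 1050 nM, so compound 3 sits at the higher number of the two.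

The change cyclohexylsulfanyl in place of cyclopentyloxy on an aromatic carbon gave an at least 180-fold higher number from compound 1 to compound 2 (2.26 log units; beyond the scatter), a result that reaches (the limit of >= 192000 nM in this assay, at which 1 of the 3 values shown sits). Compound 4 `Cc1cnc(Nc2ccc(C#N)cc2)nc1SC1CCCCC1` arises from compound 3 by the same kind of change, (cyclohexylsulfanyl in place of cyclopentyloxy on an aromatic carbon); here the place is ortho to a methyl group, whereas in compound 1 it was meta to a methyl group. A similarly large rise is expected, a 20-fold higher number from compound 3 to compound 4 (1.30 log units; beyond the scatter), resting on the step of an at least 180-fold higher number from compound 1 to compound 2 (2.26 log units; beyond the scatter). Compound 4 is estimated at 200000 nM, most likely again reported only as a limit.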

Compound 4, half-maximal cytotoxic concentration: 33400 nM
For compound 4 the middle estimate is 6.0-fold (0.78 log units) above the measured one, and the stated range ends above it.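

In this assay, cyclohexylsulfanyl in place of cyclopentyloxy again gives a higher number, with a 3.3-fold higher number from compound 3 to compound 4 (0.52 log units; beyond the scatter), so the direction carries over to the second core but the size does not: the same change on two cores in this assay, an at least 180-fold higher number (2.26 log units; beyond the scatter) from compound 1 to compound 2 and a 3.3-fold higher number (0.52 log units; beyond the scatter) from compound 3 to compound 4, at least 54-fold (1.73 log units) apart, beyond the scatter of two such steps

For compound 2, >= 192000 nM is a limit of the assay and not a number, so the earlier step has no exact size. Going by these compounds alone, with only two pairs, these results show that the size of this change depends on the core, but not why, or what it would do on a further core.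

From the compounds shown here alone, it stays open whether the sulfur or the six-membered ring accounts for the rise, and a cyclohexyloxy or cyclopentylsulfanyl group on either core would separate the two. Going by these compounds, how a cyclohexylamino group would behave in this place also stays open.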